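The source may report more compounds than this note shows. Statements on the series, on what has been measured and on what is new or still open speak of the compounds shown alone.

Compound 3, with the structure `COc1cnc(C(=O)CCCCCCc2ccccc2)o1`, is one of three measured compounds that share a long chain ending in a phenyl group and differ only in the aromatic ring on the carbonyl carbon. In an assay on HEK-293T cells for inhibition of diacylglycerol lipase-alpha (Homo sapiens), read by colorimetric assay (on this read-out lower numbers stand for stronger inhibition and higher numbers for weaker inhibition), compound 3 gives only a limit, > 10000 nM. Compound 1, `O=C(CCCCCCc1ccccc1)c1nncs1`, likewise returns a limit in this assay, > 10000 nM. Compound 2, `COc1coc(C(=O)CCCCCCc2ccccc2)n1`, also reaches only a limit in this assay, > 10000 nM. All three values therefore sit at the same point, (the limit of > 10000 nM in this assay, at which 3 of the 3 values shown sit), and the steps between them cannot be read: a step that the two limits leave unreadable from compound 1 to compound 2, a step that the two limits leave unreadable from compound 1 to compound 3 and a step that the two limits leave unreadable from compound 2 to compound 3 are all of unreadable size.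

Compound 4, `Cc1ccc(-c2cnc(C(=O)CCCCCCc3ccccc3)o2)nc1`, takes the next step from compound 3: 5-methylpyridin-2-yl in place of methoxy on an aromatic carbon. For the measured compounds named here, no measured step bears on this change, since every comparison among compounds 1, 2 and 3 is hidden by the limit, so the size and direction of the step from compound 3 to compound 4 in this assay cannot be inferred from what is known. Any number for compound 4 is thus a guess with wide bounds; compound 4 is expected to give about 3000 nM, within a range from 300 nM to 30000 nM, which would correspond to an estimated step of an at least 3.3-fold lower number from compound 3 to compound 4 (0.52 log units; beyond the scatter).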

Compound 4, half-maximal inhibitory concentration: > 10000 nM
Compound 4: only a limit was reported (the forecaster's own chance of this, stated with the estimate: 45%); at least 3.3-fold (0.52 log units) between middle value and limit.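

In this assay compound 4 gives only a limit, > 10000 nM. The step between compound 3 and compound 4 therefore cannot be read, and all four compounds stand at the same point: the limit of > 10000 nM in this assay, at which 4 of the 4 values shown sit. The compounds shown leave open how strongly any of them inhibits the enzyme, and whether these changes on the shared core alter inhibition at all.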